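A few compounds are considered here, and "the series" means these few. Any claim that something is new, unique, unknown or untested is made for them only; others in the source may bear on it.

Measured compounds:
Compound 1 `O=C(Nc1nc(-c2cc3ccccc3o2)cs1)Nc1ccccc1F`: 2630 nM
Compound 2 `O=C(Nc1ccc(I)cc1)Nc1nc(-c2cc3ccccc3o2)cs1`: 62000 nM
Compound 3 `O=C(Nc1cccc([N+](=O)[O-])c1)Nc1nc(-c2cc3cc(Br)ccc3o2)cs1`: 159000 nM

These three share one core and differ in the group on an amide-type nitrogen. In a physicochemical assay, with a stated time of 6 min (a lower number here means a stronger inhibitor, a higher number a weaker inhibitor), compound 3 gives the highest number of the three, 159000 nM; compound 2 gives 62000 nM and compound 1 gives 2630 nM, both beyond the scatter from compound 3. Compound 4 `O=C(Nc1nc(-c2cc3cc(Br)ccc3o2)cs1)Nc1ccccc1[N+](=O)[O-]` has not been measured yet. It differs from compound 3 as follows: 2-nitrophenyl in place of 3-nitrophenyl on an amide-type nitrogen. Among the compounds with values here, the one measured step that bears on this is a 24-fold higher number from compound 1 to compound 2 (1.37 log units; beyond the scatter); there the group on the same nitrogen changed from 2-fluorophenyl to 4-iodophenyl, so both the group and its name changed at once, and it is only a loose guide. Taken at face value, it points toward a lower number for a 2-substituted phenyl, so a moderate step down is expected for compound 4, a 4.0-fold lower number from compound 3 to compound 4 (0.60 log units; beyond the scatter). For compound 4 the estimate in this assay is 40000 nM, with a range from 8000 nM to 250000 nM.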

Compound 4, half-maximal inhibitory concentration: 166000 nM
Beside the measured number, compound 4's estimate is 4.2-fold (0.62 log units) below it, within the range that was stated.
By their numbers in this assay, from the lowest: compound 1; then compound 2; then compounds 3 and 4 (each within the scatter of the next).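

Putting 2-nitrophenyl in place of 3-nitrophenyl on the amide-type nitrogen gives a 1.0-fold higher number from compound 3 to compound 4 (0.02 log units; within the scatter) in this assay, so this assay does not tell the two compounds apart. This is the first step shown in which the atoms stay the same and only their arrangement in the group differs, whereas the earlier step changed the substituent and its place on the phenyl ring together; for the nitrophenyl group on this core, moving from the 3-nitrophenyl to the 2-nitrophenyl arrangement leaves the number within the scatter. Nothing measured here bears on why the two compounds read alike.

Still open, going by these compounds, is whether 4-nitrophenyl would also fall within the scatter of compound 3. Also open, on these data alone, is whether an amine or a carboxylic acid in place of the nitro group would shift the number.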